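The compounds below may be only part of what the source reports. "The series", "measured", "known", "first", "only" and "open" are said of these compounds alone.

Working notes. Compound 3 `Cc1ccc(-n2nc(C(=O)Nc3ccc(Oc4ncnc5[nH]ccc45)c(F)c3)c(C)cc2=O)cc1` gives 20400 nM in a functional assay on PC-3 cells (Homo sapiens) for cytotoxicity, read by MTT assay, with a stated time of 72 h (a lower number here means a stronger inhibitor, a higher number a weaker inhibitor), the highest of the three numbers. Compound 2 `Cc1cc(=O)n(-c2ccc(F)cc2)nc1C(=O)Nc1ccc(Oc2ncnc3[nH]ccc23)c(F)c1` gives 17300 nM in this assay, and the step of a 1.2-fold higher number from compound 2 to compound 3 (0.07 log units; within the scatter) lies within the scatter. Compound 1 `Cc1cc(=O)n(-c2ccc(Br)cc2F)nc1C(=O)Nc1ccc(Oc2ncnc3[nH]ccc23)cc1` gives 2730 nM in this assay, the lowest number of the three and beyond the scatter from compound 3.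

Compound 4 `Cc1cc(=O)n(-c2ccc(Br)cc2F)nc1C(=O)Nc1ccc(Oc2ncnc3[nH]ccc23)c(F)c1` carries the change (4-bromo-2-fluorophenyl in place of 4-methylphenyl on an aromatic nitrogen). Within the data shown here, no measured step exchanges these two groups directly; the only single step known, from compound 2 to compound 3, is flat. Compound 1, which carries the same 4-bromo-2-fluorophenyl group, shows a clearly lower number than compound 3, though it also lacks the fluoro on the anilide ring, so it is a hint and not a rule. The expected step is therefore toward a lower number, of moderate size: a 4.5-fold lower number from compound 3 to compound 4 (0.66 log units; beyond the scatter). Compound 4 is estimated at 4500 nM in this assay, with a range of 1500 nM to 14000 nM.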

Compound 4, half-maximal inhibitory concentration: 13300 nM
Compound 4: the middle estimate sits 3.0-fold (0.47 log units) below what was measured; low and high end bracket the measured number.
By their numbers in this assay, from the lowest: compound 1; then compounds 4, 2 and 3 (each within the scatter of the next).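

With the fluoro on the aromatic carbon held in place, 4-bromo-2-fluorophenyl, 4-methylphenyl and 4-fluorophenyl on the aromatic nitrogen are not told apart in this assay: a 1.5-fold lower number from compound 3 to compound 4 (0.19 log units; within the scatter) and a 1.3-fold lower number from compound 2 to compound 4 (0.11 log units; within the scatter) both stay within the scatter. Among these compounds, the 4-bromo-2-fluorophenyl group alone therefore does not carry the low number of compound 1, and the one new step beyond the scatter, a 4.9-fold higher number from compound 1 to compound 4 (0.69 log units; beyond the scatter), is fluoro in place of hydrogen on an aromatic carbon. No evidence on hand bears on this result.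

On these data alone, whether the fluoro step holds with 4-methylphenyl or 4-fluorophenyl on the aromatic nitrogen remains open. So does whether an amine or a carboxylic acid in place of that aryl group would give a step beyond the scatter.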